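The source may hold more compounds than are shown below. What is called first, only, known or untested is meant among the compounds shown, and "the series" means these compounds.

Working notes on the series. Three compounds have a number in a functional assay on MCF7 cells (Homo sapiens) for cytotoxicity, read by MTT assay, with a stated time of 72 h; a lower number here means a stronger inhibitor, a higher number a weaker inhibitor. Compound 3 `CN1CCN(CCCCOc2c(OCc3ccco3)cc(O)c3c(=O)cc(-c4ccccc4)oc23)CC1` gives 2770 nM in this assay. Compound 1 `CN1CCN(CCCCOc2c(OCc3ccccc3)cc(O)c3c(=O)cc(-c4ccccc4)oc23)CC1` gives 2930 nM and compound 2 `Cc1ccc(COc2cc(O)c3c(=O)cc(-c4ccccc4)oc3c2OCCCCN2CCN(C)CC2)cc1` gives 2220 nM. Compound 3 thus sits with the other two: the steps of a 1.1-fold lower number from compound 1 to compound 3 (0.02 log units; within the scatter) and a 1.2-fold higher number from compound 2 to compound 3 (0.10 log units; within the scatter) are both within the scatter, as is a 1.3-fold lower number from compound 1 to compound 2 (0.12 log units; within the scatter), so no one of the three separates from the others.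

Compound 4 `CN1CCN(CCCCOc2c(OCc3cccs3)cc(O)c3c(=O)cc(-c4ccccc4)oc23)CC1` differs from compound 3 by thiophen-2-yl in place of furan-2-yl on a saturated chain carbon bound to an oxygen on an aromatic ring. Among the compounds with values here, the steps that bear on this are the two earlier swaps of the group on the saturated chain carbon bound to the oxygen on the aromatic ring, from compound 1 to compound 3 and from compound 2 to compound 3, and neither moved the number beyond the scatter. Three different groups at this place gave three numbers within the scatter of one another. The expectation for compound 4 is therefore no step beyond the scatter, a 1.1-fold lower number from compound 3 to compound 4 (0.03 log units; within the scatter). Compound 4 is estimated at 2600 nM in this assay, with a range from 1300 nM to 5200 nM.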

Compound 4, half-maximal inhibitory concentration: 3180 nM
The estimate for compound 4 lay 1.2-fold (0.09 log units) below the measured number; the range from low to high includes it.
By their numbers in this assay, from the lowest: compounds 2, 3, 1 and 4 (each within the scatter of the next).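

Changing furan-2-yl to thiophen-2-yl keeps the ring size and heavy-atom count and exchanges only the ring's oxygen for sulfur; in this assay this gives a 1.1-fold higher number from compound 3 to compound 4 (0.06 log units; within the scatter). Thiophen-2-yl also stays within the scatter of the two carbon-only aryl groups, with a 1.1-fold higher number from compound 1 to compound 4 (0.04 log units; within the scatter) and a 1.4-fold higher number from compound 2 to compound 4 (0.16 log units; within the scatter), so phenyl, 4-methylphenyl, furan-2-yl and thiophen-2-yl on a saturated chain carbon bound to an oxygen on an aromatic ring do not separate from one another. Nothing available explains why the number stays flat at this place.

On these data alone, all four groups are aromatic rings, so it remains open whether an amine, a carboxylic acid or a longer alkyl chain at this place would move the number. The four compounds also share the rest of their structure, leaving the effect of any change elsewhere unknown.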